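Swapping an Aromatic Amide for a Saturated Urea

This account rests on a few compounds, and the source may have more. Where it says the series, first, only, none or still open, it means among the compounds named here.

Compounds measured so far:
- compound 1, `C(#Cc1nc2c(s1)CN(C1CCCCC1)CC2)c1ccccc1`: in an assay on HEK293 cells for positive allosteric modulation of metabotropic glutamate receptor 5 (Homo sapiens), read by FLIPR, with a stated time of 1 h (on this read-out higher numbers stand for an effect only at larger amounts of compound and lower numbers for an effect already at smaller amounts), compound 1 reaches only a limit of the assay, > 10000 nM.
- compound 2, `CC(=O)N1CCc2nc(C#Cc3ccccc3)sc2C1`: in this assay compound 2 likewise stops at a limit, > 10000 nM.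
- compound 3, `Cc1nc(C(=O)N2CCc3nc(C#Cc4ccccc4)sc3C2)cs1`: in this assay compound 3 gives 220 nM.

Among the measured compounds shown here, compound 3 therefore stands as the only real number among the three; the other two values are limits, (the limit of > 10000 nM in this assay, at which 2 of the 3 values shown sit). The steps reaching it are large: an at least 45-fold lower number from compound 1 to compound 3 (1.65 log units; beyond the scatter) and an at least 45-fold lower number from compound 2 to compound 3 (1.65 log units; beyond the scatter), while the step that the two limits leave unreadable from compound 1 to compound 2 cannot be read at all.

Compound 4, `O=C(N1CCCC1)N1CCc2nc(C#Cc3ccccc3)sc2C1`, differs from compound 3 by a single exchange: pyrrolidin-1-yl in place of 2-methyl-1,3-thiazol-4-yl on a carbonyl carbon. The step from compound 2 to compound 3 bears directly on this change, because an at least 45-fold lower number from compound 2 to compound 3 (1.65 log units; beyond the scatter) shows how much the group on that carbonyl carbon decides the outcome. Pyrrolidin-1-yl is neither the small methyl of compound 2 nor the aromatic ring of compound 3, so a weakening is expected, though not the full loss seen in compound 2. Compound 4 is estimated at 3000 nM, between 500 nM and 10000 nM, which means an expected step of a 14-fold higher number from compound 3 to compound 4 (1.13 log units; beyond the scatter).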

Compound 4, half-maximal effective concentration: 9.8 nM
Estimate against measurement, compound 4: 310-fold (2.49 log units) above; measured number outside the range, below it.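

In this assay, the group on this carbonyl carbon need not be aromatic: pyrrolidin-1-yl, a non-aromatic ring with no hydrogen-bond acceptors counted, in place of 2-methyl-1,3-thiazol-4-yl gives a 22-fold lower number from compound 3 to compound 4 (1.35 log units; beyond the scatter). The same group also stands well apart from the two inactive compounds, with an at least 1000-fold lower number from compound 2 to compound 4 (3.00 log units; beyond the scatter) and an at least 1000-fold lower number from compound 1 to compound 4 (3.00 log units; beyond the scatter). Both of these steps start from a limit, not a number, and their full size cannot be read: the limit of > 10000 nM in this assay, at which 2 of the 4 values shown sit.

Still open, from the compounds shown here alone, is whether the gain belongs to pyrrolidin-1-yl itself or extends to other groups on that carbonyl carbon, such as piperidin-1-yl, morpholin-4-yl or an open-chain diethylamino group. Nor can a single exchange of one ring for another tell which feature of that exchange accounts for the step.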